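Moving a Methyl Group on the Triazole Aryl Ring

The compounds below may be only part of what the source reports. "The series", "measured", "known", "first", "only" and "open" are said of these compounds alone.

In a functional assay on HepG2 cells (Homo sapiens) for antiproliferative activity, read by MTT assay, with a stated time of 24 h (a higher number here means a weaker inhibitor, a lower number a stronger inhibitor), compound 1 `Cc1ccccc1-n1cc(-c2ccccc2NS(=O)(=O)c2c[nH]c(=O)[nH]c2=O)nn1` gives 13900 nM.
In this assay compound 2 `Cc1cccc(-n2cc(-c3ccccc3NS(=O)(=O)c3c[nH]c(=O)[nH]c3=O)nn2)c1` gives 3620 nM.
In this assay compound 3 `Cc1ccccc1-n1cc(-c2ccc(NS(=O)(=O)c3c[nH]c(=O)[nH]c3=O)cc2)nn1` gives 14500 nM.

Compound 1 and compound 2 share a core and differ in a single place: 3-methylphenyl in place of 2-methylphenyl on an aromatic nitrogen. This change gives a 3.8-fold lower number from compound 1 to compound 2 (0.58 log units; beyond the scatter), a shift that stands beyond the usual scatter of the measurement. Compound 3 carries the same 2-methylphenyl group as compound 1 on a different core; the difference between the two cores is not broken down here. The half-maximal inhibitory concentrations of compound 1 and compound 3 lie within the scatter of each other, so no order can be read between them.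

Compound 4 `Cc1cccc(-n2cc(-c3ccc(NS(=O)(=O)c4c[nH]c(=O)[nH]c4=O)cc3)nn2)c1` is not yet measured. It differs from compound 3 in one place: 3-methylphenyl in place of 2-methylphenyl on an aromatic nitrogen. The place is described in the same words as for the change from compound 1 to compound 2, so this is the same change. The expectation for compound 4 therefore rests on compound 1 and compound 2, where the change gave a 3.8-fold lower number from compound 1 to compound 2 (0.58 log units; beyond the scatter), and on the value of compound 3, 14500 nM, as starting point. A similar step is expected, a 3.6-fold lower number from compound 3 to compound 4 (0.56 log units; beyond the scatter), though with a single precedent the size is uncertain. For compound 4 the estimate in this assay is 4000 nM, with a likely range from 1500 nM to 11000 nM.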

Compound 4, half-maximal inhibitory concentration: > 20000 nM
Compound 4 gave a limit, no number; the forecaster's own chance of this, stated with the estimate: 2%; middle value at least 5.0-fold (0.69 log units) away from the limit.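

In this assay compound 4 gives > 20000 nM, which is a limit of the assay and not a number. Placing 3-methylphenyl where 2-methylphenyl stood on the aromatic nitrogen gives an at least 1.3-fold higher number from compound 3 to compound 4 (0.13 log units; that floor lies within the scatter), so the gain seen on the core of compound 1 does not carry over to the core of compound 3, and the two steps clearly differ: the same change on two cores in this assay, a 3.8-fold lower number (0.58 log units; beyond the scatter) from compound 1 to compound 2 and an at least 1.3-fold higher number (0.13 log units; that floor lies within the scatter) from compound 3 to compound 4, at least 5.2-fold (0.72 log units) apart, beyond the scatter of two such steps What this does not show is the true size of the step on the core of compound 3, or why the two cores respond differently, and only one compound stands at the limit: the limit of > 20000 nM in this assay, at which 1 of the 4 values shown sits.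

Among the compounds shown here, with only two matched pairs, it stays open whether this split between the cores is specific to the methyl group. A methoxy group or a chlorine atom in its place on the same phenyl ring might or might not divide the two cores in the same way.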